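From Cyclohexyl to Benzyl on the Amide Nitrogen

This account rests on a few compounds, and the source may have more. Where it says the series, first, only, none or still open, it means among the compounds named here.

Two compounds sharing one core have been characterised in a functional assay on HEK293T cells for agonist activity at histamine H2 receptor (Homo sapiens), read by beta-arrestin recruitment; on this read-out lower numbers stand for an effect already at smaller amounts and higher numbers for an effect only at larger amounts of compound. Compound 1 `Cc1nc(N)sc1CCCN/C(N)=N/C(=O)NC1CCCCC1` gives 389 nM in this assay. Compound 2 `Cc1nc(N)sc1CCCN/C(N)=N/C(=S)N[C@H](C)c1ccccc1` gives 372 nM in this assay. Of the two numbers compound 1 holds the marginally larger one, but its gap to compound 2 lies within the scatter and so does not set the two apart. Going by the values given here, no pair of measured compounds differing in a single place is available, so no measured step can guide the next move. Compound 3 `Cc1nc(N)sc1CCCN/C(N)=N/C(=O)NCc1ccccc1` has not yet been measured. It differs from compound 1 by benzyl in place of cyclohexyl on an amide-type nitrogen. Without a measured step to lean on, and with compound 1 and compound 2 sitting so close in this assay, a change of no more than the scatter is expected, in no firm direction. Compound 3 is therefore estimated at 350 nM, with a range from 150 nM to 900 nM. The step this estimate implies is a 1.1-fold lower number from compound 1 to compound 3 (0.05 log units; within the scatter).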

Compound 3, half-maximal effective concentration: 100 nM
For compound 3 the middle estimate is 3.5-fold (0.54 log units) above the measured one, and the stated range ends above it.
By their numbers in this assay, from the lowest: compound 3; then compounds 2 and 1 (each within the scatter of the next).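

At this amide-type nitrogen the choice of group does register in this read-out: in (this assay), benzyl in place of cyclohexyl gives a modest step beyond the scatter (a 3.9-fold lower number from compound 1 to compound 3 (0.59 log units; beyond the scatter)). The exchange replaces a non-aromatic ring with an aromatic one and goes from 6 heavy atoms to 7, while both groups count no hydrogen-bond donors or acceptors and no net charge. No supporting data are available to explain the step.

The shown compounds change ring type and size of the group together, so they cannot say which of the two goes with the lower number. Cyclohexylmethyl or phenyl on the same nitrogen would separate the two, and 2-phenylethyl would show how a longer chain fares.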